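From furan-2-yl to thiophen-2-yl on the shared core

The source may report more compounds than this note shows. Statements on the series, on what has been measured and on what is new or still open speak of the compounds shown alone.

Values measured in a functional assay on HCT-116 cells (Homo sapiens) for inhibition, read by sulforhodamine B assay, with a stated time of 48 h, tested at 50 uM (on this read-out higher numbers stand for more inhibition of growth at the one concentration tested and lower numbers for less inhibition of growth), are as follows.
- compound 1 `COc1ccc(/C=C/C(=O)/C=C/c2ccc(OCc3cn(CCCCOc4cc(=O)oc5ccccc45)nn3)c(OC)c2)cc1OC` gives 55%
- compound 2 `COc1cc(/C=C/C(=O)/C=C/c2cccc3ccccc23)ccc1OCc1cn(CCCCOc2cc(=O)oc3ccccc23)nn1` gives 56%
- compound 3 `COc1cc(/C=C/C(=O)/C=C/c2ccco2)ccc1OCc1cn(CCCCOc2cc(=O)oc3ccccc23)nn1` gives 47%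

Compound 3 does not stand apart from the other two measured compounds. Its value lies within the usual scatter of both, as the step of a number 8 percentage points lower from compound 1 to compound 3 (within the scatter) and the step of a number 9 percentage points lower from compound 2 to compound 3 (within the scatter) show.

Compound 4 `COc1cc(/C=C/C(=O)/C=C/c2cccs2)ccc1OCc1cn(CCCCOc2cc(=O)oc3ccccc23)nn1` has not yet been measured. The change leading to it is thiophen-2-yl in place of furan-2-yl on a double-bonded chain carbon bound to a double-bonded chain carbon and both groups are a five-membered aromatic ring with 1 hetero atom, with sulfur entering where oxygen leaves.

Going by the values given here, no measured step makes this exchange itself. The closest evidence comes from the three exchanges at the same place on the chain, which are the two steps above and the step of a number 1 percentage points higher from compound 1 to compound 2 (within the scatter) and none of them goes beyond the scatter. In this assay no shift beyond the scatter is therefore expected here.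

The expected step is a number 3 percentage points higher from compound 3 to compound 4 (within the scatter) and it rests on these three small steps alone. For compound 4 the estimated value is 50% (expected range 38% to 62%).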

Compound 4, percent growth inhibition at one concentration: 41%
The estimate for compound 4 lay 9 percentage points above the measured number; low and high end bracket the measured number.
By their numbers in this assay, from the lowest: compounds 4, 3, 1 and 2 (each within the scatter of the next, the first and the last beyond it).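

In this assay this place on the chain, a double-bonded chain carbon bound to a double-bonded chain carbon, now gives its first steps beyond the scatter, both with thiophen-2-yl entering (a number 14 percentage points lower from compound 1 to compound 4 (beyond the scatter); a number 15 percentage points lower from compound 2 to compound 4 (beyond the scatter)). The exchange of furan-2-yl for thiophen-2-yl, with sulfur entering where oxygen leaves, does not separate the two five-membered aromatic rings (a number 6 percentage points lower from compound 3 to compound 4 (within the scatter)). Compound 3 therefore goes against any rule that a five-membered aromatic ring here falls beyond the scatter of the 3,4-dimethoxyphenyl and naphthalen-1-yl groups, since that separation holds for thiophen-2-yl alone, and no measurement at hand explains it.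

The compounds shown leave open whether pyridin-2-yl or a phenyl ring carrying an amine or a carboxylic acid at this place would fall with compound 4 or with compound 1 and compound 2. They also leave open whether the same differences would hold with a longer chain elsewhere on the shared core, or at other concentrations, as each number comes from a single concentration.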